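One methoxy added to compound 2

This account rests on a few compounds, and the source may have more. Where it says the series, first, only, none or still open, it means among the compounds named here.

Compound 1 `C=C(Br)C(=O)Nc1ccc(/C=C/C(=O)c2cc(OC)c(OC)c(OC)c2)cc1` gives 1100 nM
Compound 2 `C=C(Br)C(=O)Nc1ccc(C(=O)/C=C/c2ccccc2)cc1` gives 1500 nM

Both compounds were tested in an ADME assay on CCRF-CEM cells (Homo sapiens) for antiproliferative activity, with a stated time of 48 h; on this read-out lower numbers stand for stronger inhibition and higher numbers for weaker inhibition. A single measurement of this kind carries some natural scatter, so small gaps between values should not be over-read. Compound 2, at 1500 nM, and compound 1, at 1100 nM, lie within that scatter of each other, and the two cannot be ranked.

The next compound to be tested is compound 3 `C=C(Br)C(=O)Nc1ccc(C(=O)/C=C/c2cccc(OC)c2)cc1`. It differs from compound 2 in one place, where methoxy stands in place of hydrogen on an aromatic carbon (methoxy in place of hydrogen on an aromatic carbon). The methoxy sits on a six-membered aromatic ring of carbon only, meta to a large group.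

Among the compounds with values here, no measured pair here shows this change by itself, so its size cannot be read directly from the data. The cautious expectation is a small move toward a lower number, or none beyond the scatter. The estimated result is a 1.4-fold lower number from compound 2 to compound 3 (0.13 log units; within the scatter), which is expected to stay within the scatter. For compound 3 the estimate is 1100 nM, with an expected range from 450 nM to 2700 nM.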

Compound 3, half-maximal inhibitory concentration: 1800 nM
Compound 3: middle estimate off by 1.6-fold (0.21 log units), on the low side, and the stated range covers the measured number.
By their numbers in this assay, from the lowest: compounds 1, 2 and 3 (each within the scatter of the next).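

Within the data shown here, replacing hydrogen with methoxy, in the change from phenyl to 3-methoxyphenyl, gives a 1.2-fold higher number from compound 2 to compound 3 (0.08 log units; within the scatter) in this assay and this small step is the first direct reading of the change. It lies within the ordinary scatter of repeated measurements, so at this carbon of the six-membered aromatic ring, meta to a large group, the data show neither a gain nor a loss in antiproliferative activity, and this one added methoxy is tolerated without a change that can be told apart from that scatter. No independent measurement here bears on why the number stays so close, and the explanation therefore remains unknown.

From the compounds shown here alone, this single pair speaks only for methoxy at this one carbon, in this one compound series, so the effect of methoxy on another carbon of the same ring remains open. It also leaves open whether an amine, a carboxylic acid or a longer chain such as ethoxy at this same carbon would move the number beyond the scatter.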